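The source may report more compounds than this note shows. Statements on the series, on what has been measured and on what is new or still open speak of the compounds shown alone.

Measured so far:
compound 1 `COc1cc(C(C)=O)ccc1OCCCN1CCC(C(NC(C)=O)(c2ccc(F)cc2)c2ccc(F)cc2)CC1`: 63.1 nM
compound 2 `COc1cc(OCCCN2CCC(C(c3ccc(F)cc3)c3ccc(F)cc3)CC2)ccc1C(C)=O`: 3.16 nM

In a functional assay (aorta) with Oryctolagus cuniculus as the target (on this read-out lower numbers stand for tighter binding and higher numbers for weaker binding), compound 2 stands at the lowest of the two numbers, with compound 1 a higher value, beyond the scatter. The next compound, compound 3 `COc1ccc(OCCCN2CCC(C(c3ccc(F)cc3)c3ccc(F)cc3)CC2)cc1`, is not yet measured in this assay. It differs from compound 2 in one place: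

4-methoxyphenyl in place of 4-acetyl-3-methoxyphenyl on an oxygen on a saturated carbon

For the measured compounds named here, no measured pair shows this change, so its size is open. The expectation is a moderate rise in the number, beyond the scatter, rather than no change. Compound 3 is thus estimated at 15 nM, range 3 nM to 80 nM, a step of a 4.7-fold higher number from compound 2 to compound 3 (0.68 log units; beyond the scatter) expected.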

Compound 3, dissociation constant: 2.51 nM
The estimate for compound 3 lay 6.0-fold (0.78 log units) above the measured number; the whole stated range lies above it.
By their numbers in this assay, from the lowest: compounds 3 and 2 (each within the scatter of the next); then compound 1.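

In this assay, 4-methoxyphenyl in place of 4-acetyl-3-methoxyphenyl on an oxygen on a saturated carbon gives a 1.3-fold lower number from compound 2 to compound 3 (0.10 log units; within the scatter) and this shows that the position tolerates the loss of the acetyl carbonyl. In this pair, the low number of compound 2 does not depend on the acetyl group. From the compounds shown here alone, whether an amine or a carboxylic acid on this aromatic ring, or a longer chain leading to the oxygen, would hold the number at this level remains open. Nothing shown gives a reason for this result.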